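Amino for methyl at a cytotoxicity limit

The compounds below may be only part of what the source reports. "The series", "measured", "known", "first", "only" and "open" are said of these compounds alone.

In an ADME assay on BJ cells (Homo sapiens) for cytotoxicity, with a stated time of 72 h (on this read-out lower numbers stand for an effect already at smaller amounts and higher numbers for an effect only at larger amounts of compound), the measured compounds read as follows:
Compound 1 `COc1cc2nc(Cl)nc(-n3nc(-c4ccccn4)nc3N)c2cc1OC` gives > 13000 nM as a limit
Compound 2 `COc1cc2nc(C)nc(-n3nc(-c4ccccn4)nc3N)c2cc1OC` gives > 13000 nM as a limit

Compound 2 has no number of its own, only > 13000 nM as a limit of the assay. The evidence so far is the limit of > 13000 nM in this assay, at which 2 of the 2 values shown sit, and nothing more.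

The next compound is compound 3 `COc1cc2nc(N)nc(-n3nc(-c4ccccn4)nc3N)c2cc1OC` with one change from compound 2 in the shared core. That change is amino in place of methyl, counted as amino in place of methyl on an aromatic carbon and sitting on an aromatic carbon between two ring nitrogen atoms.

Within the data shown here, the only measured step at this place is a step that the two limits leave unreadable from compound 1 to compound 2 with methyl in place of chloro. That step has no readable size, so it offers nothing to scale from. Since compound 2 sits at > 13000 nM as a limit, no step beyond the scatter is expected in this assay and no direction can be named. Another limit is the likeliest report. The expected step is a number no higher from compound 2 to compound 3 (the limit leaves the size open) in this estimate. Compound 3 is estimated at 13000 nM with 5000 nM to 30000 nM as the expected range.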

Compound 3, half-maximal effective concentration: > 27000 nM
Compound 3 ended at the assay's limit; the forecaster's own chance of this, stated with the estimate: 75%; middle value at least 2.0-fold (0.31 log units) away from the limit.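

Among these compounds, compound 1, compound 2 and compound 3 all end at limits of the assay rather than at numbers in this assay, so no step among them can be read. The compounds shown leave open where each one's real value lies, and whether chloro, methyl or amino on that aromatic carbon changes the cytotoxicity at all.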